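This account rests on a few compounds, and the source may have more. Where it says the series, first, only, none or still open, it means among the compounds named here.

Measured compounds:
Compound 1, `Cc1ccc(-c2cc(/N=C3/NC(=O)CS3)cs2)cc1`, gives in a functional assay on HT-29 cells (Homo sapiens) for cytotoxicity, read by MTT assay, with a stated time of 72 h (on this read-out higher numbers stand for weaker inhibition and lower numbers for stronger inhibition), only a limit, > 50000 nM.
Compound 2, `O=C1N/C(=N/c2csc(-c3ccc(Cl)cc3)c2)S/C1=C\c1ccccc1`, gives in this assay 10500 nM.

Among the compounds with values here, compound 2 is the only compound here with a true number; the other value is a limit of the assay, (the limit of > 50000 nM in this assay, at which 1 of the 2 values shown sits), so no measured step between compounds can be drawn, and nothing is known about how big a change of this kind usually is.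

Compound 3, `Cc1ccc(/C=C2\S/C(=N\c3csc(-c4ccc(Cl)cc4)c3)NC2=O)cc1`, is compound 2 with one small change: methyl in place of hydrogen on an aromatic carbon, which reads one bond further out as phenyl to 4-methylphenyl. The change adds a single carbon and no ring, donor, acceptor or charge.

Within the data shown here, with no measured step to lean on, the expectation for compound 3 is a step close to that of compound 2, of a size that stays within the scatter of repeated measurements, in no clear direction. Compound 3 is therefore estimated at 9000 nM, between 3500 nM and 25000 nM, an expected step of a 1.2-fold lower number from compound 2 to compound 3 (0.07 log units; within the scatter).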

Compound 3, half-maximal inhibitory concentration: 6400 nM
Compound 3: middle estimate off by 1.4-fold (0.15 log units), on the high side; low and high end bracket the measured number.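

In this assay, methyl in place of hydrogen on an aromatic carbon, para to a large group, gives a 1.6-fold lower number from compound 2 to compound 3 (0.22 log units; within the scatter), so this change leaves the two compounds indistinguishable on this read-out. This is the first measured step among the compounds shown, and it shows that adding a single carbon at this place on the phenyl ring produces no change that can be told from ordinary repeat-to-repeat variation. Nothing available here bears on why the step has this size.

One small group at one place says little about the position as a whole. From the compounds shown here alone, whether an amine, a carboxylic acid or a longer chain such as propyl would move the number beyond the scatter remains open, as does whether a hydrogen-bonding group would behave differently from methyl here.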